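The source may report more compounds than this note shows. Statements on the series, on what has been measured and on what is new or still open speak of the compounds shown alone.

Measured so far in a functional assay on the whole organism (strain Sprague-Dawley) for inhibition, with Rattus norvegicus as the target, with a stated time of 0.5 h, at a dose of 5 mg/kg by the oral route; a higher number here means more inhibition at the dose given (going by the name of the read-out), a lower number less inhibition:
compound 1, `CCCSc1nc(N[C@@H]2C[C@H]2c2ccc(F)c(F)c2)c2nnn([C@@H]3C[C@H](OC(=O)CC)[C@@H](O)[C@H]3O)c2n1`, compound 1 gives 44.5%
compound 2, `CCCSc1nc(N[C@@H]2C[C@H]2c2ccc(F)c(F)c2)c2nnn([C@@H]3C[C@H](OC(=O)C(C)(C)C)[C@@H](O)[C@H]3O)c2n1`, compound 2 gives "not active" (no number reported)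

Compound 2 stands without a number: in this assay compound 2 is recorded as "not active" (no number reported), whereas compound 1 gives 44.5%. Within the data shown here, no step is computed for that pair; the two values show only that compound 1 has a measurable read-out and compound 2 does not.

Compound 3, `CCCSc1nc(N[C@@H]2C[C@H]2c2ccc(F)c(F)c2)c2nnn([C@@H]3C[C@H](OCCOC(=O)c4cccnc4)[C@@H](O)[C@H]3O)c2n1`, differs from compound 2 in one place: 2-(((pyridin-3-yl)carbonyl)oxy)ethyl in place of (tert-butyl)carbonyl on an oxygen on a saturated carbon.

Among the measured compounds shown here, no measured pair gives a step for this change, so its size is open. Starting from a compound 2 that shows no measurable inhibition, any numerical read-out for compound 3 would be a move upward in this assay; a step of modest size, not certainly beyond the scatter, is expected rather than none.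

Compound 3 is expected to give about 20% in this assay, within 0% to 50%, with a real chance that only "not active" is again reported.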

Compound 3, a percentage reported as inhibition, in the whole organism at one dose (the size of the read-out at that dose, not a potency): "not active" (no number reported)
Compound 3 has no reported number here; no gap can be computed for the estimate.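

In this assay compound 2 gives "not active" (no number reported) and compound 3 gives "not active" (no number reported), so no step can be read for this pair. The compounds shown leave open how the 2-(((pyridin-3-yl)carbonyl)oxy)ethyl and (tert-butyl)carbonyl groups compare in size of effect. No measured evidence bears on this result.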